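The source may hold more compounds than are shown below. What is called first, only, known or untested is meant among the compounds shown, and "the series" means these compounds.

Of the compounds shown here, three from this series have been measured in a functional assay on CCRF-CEM cells (Homo sapiens) for cytotoxicity; a higher number here means a weaker inhibitor, a lower number a stronger inhibitor. Compound 1 `CN(C)CCn1c(-c2cncc(-c3cc4cc(O)ccc4[nH]3)c2)cc2cc(O)ccc21` gives 5760 nM in this assay. Compound 2 `CN(C)CCCn1c(-c2cncc(-c3cc4cc(O)ccc4[nH]3)c2)cc2cc(O)ccc21` gives 14200 nM in this assay. The step between them, a 2.5-fold higher number from compound 1 to compound 2 (0.39 log units; beyond the scatter), rests on one structural change: (dimethylamino)methyl in place of dimethylamino on a saturated chain carbon, two bonds along the chain from an aromatic nitrogen. Compound 3 `CN(C)CCCOc1ccc(-c2cncc(-c3cc4ccccc4n3CCN(C)C)c2)cc1` gives 3720 nM in this assay; its value and that of compound 1 lie within the usual scatter of each other, while its number is lower than that of compound 2 by more than the scatter allows. How the core of compound 3 differs from the core of compound 1 is not broken down here; the two differ in more than one place.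

Compound 4 `CN(C)CCCOc1ccc(-c2cncc(-c3cc4ccccc4n3CCCN(C)C)c2)cc1` has not yet been measured in this assay. It stands to compound 3 as compound 2 stands to compound 1, the change being ((dimethylamino)methyl in place of dimethylamino on a saturated chain carbon, two bonds along the chain from an aromatic nitrogen). The place of the change is the same in both pairs, so this is the same change seen again on a different core. Within the data shown here, the only guide to its size is the one measured example. Because lengthening the chain gave a 2.5-fold higher number from compound 1 to compound 2 (0.39 log units; beyond the scatter), a step of similar direction and size is expected here, namely a 2.0-fold higher number from compound 3 to compound 4 (0.30 log units; within the scatter), though the different core means the size carries real uncertainty. On that basis compound 4 is expected to give about 7500 nM in this assay, with a plausible range from 3500 nM to 16000 nM.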

Compound 4, half-maximal inhibitory concentration: 4190 nM
Compound 4: the middle estimate sits 1.8-fold (0.25 log units) above what was measured; the measured number falls inside the stated range.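

In this assay the new step is a 1.1-fold higher number from compound 3 to compound 4 (0.05 log units; within the scatter), so replacing dimethylamino with (dimethylamino)methyl at this place gives no difference that can be told apart from scatter on the core of compound 3. Set beside the same change on the core of compound 1, the result still does not separate the two cores, even though only the earlier step lies beyond the scatter by itself: the same change on two cores in this assay, a 2.5-fold higher number (0.39 log units; beyond the scatter) from compound 1 to compound 2 and a 1.1-fold higher number (0.05 log units; within the scatter) from compound 3 to compound 4, 2.2-fold (0.34 log units) apart, within the scatter of two such steps. Among these compounds, this shows that the change can be carried to the second core without a clear penalty or gain, but with only one pair on each core it neither fixes a common size for the step nor proves that the size is the same on both cores.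

The compounds shown stop at 2-(dimethylamino)ethyl and 3-(dimethylamino)propyl on the aromatic nitrogen, so it remains open whether a chain ending in dimethylamino and longer than these would continue the comparison. Going by these compounds, it is also open whether a primary amine or a carboxylic acid at the end of the chain would give steps of a similar size on these two cores.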